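The source may hold more compounds than are shown below. What is called first, only, known or untested is meant among the compounds shown, and "the series" means these compounds.

In a functional assay on B16 cells (Mus musculus) for cytotoxicity, read by CCK-8 assay, with a stated time of 24 h (on this read-out higher numbers stand for weaker inhibition and lower numbers for stronger inhibition), the measured compounds read as follows:

Compound 1 (`COc1ccccc1Oc1c(N)nc(-c2ccc(C)cc2)nc1Cl`): 17400 nM
Compound 2 (`COc1ccccc1Oc1c(N)nc(-c2cccc(F)c2)nc1Cl`): 21700 nM
Compound 3 (`COc1ccccc1Oc1c(N)nc(-c2ccc(C)cc2)nc1OCCO`): 8430 nM

Compound 3 holds the lowest number of the three, and its gaps to compound 1 and compound 2 both lie beyond the scatter. Compound 4 (`COc1ccccc1Oc1c(N)nc(-c2cccc(F)c2)nc1OCCO`) carries one change from compound 3 (3-fluorophenyl in place of 4-methylphenyl on an aromatic carbon): 3-fluorophenyl in place of 4-methylphenyl, on the aromatic carbon between two ring nitrogen atoms. The same exchange gave a 1.2-fold higher number from compound 1 to compound 2 (0.10 log units; within the scatter) with chloro where compound 3 has 2-hydroxyethoxy. The step of a 2.1-fold lower number from compound 1 to compound 3 (0.31 log units; beyond the scatter) on the chloro exchange is a different change and is kept in both compound 3 and compound 4. In this assay a small rise, none beyond the scatter, is therefore expected. The expected step is a 1.2-fold higher number from compound 3 to compound 4 (0.10 log units; within the scatter) on this reasoning. Compound 4 is estimated at 10500 nM (expected range 5500 nM to 20000 nM).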

Compound 4, half-maximal inhibitory concentration: 20900 nM
Compound 4: middle estimate off by 2.0-fold (0.30 log units), on the low side; the whole stated range lies below it.
By their numbers in this assay, from the lowest: compound 3; then compounds 1, 4 and 2 (each within the scatter of the next).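

In this assay, with 2-hydroxyethoxy on the core, 3-fluorophenyl in place of 4-methylphenyl gives a 2.5-fold higher number from compound 3 to compound 4 (0.39 log units; beyond the scatter), a step beyond the scatter that the chloro pair did not show. With 3-fluorophenyl present, 2-hydroxyethoxy in place of chloro gives a 1.0-fold lower number from compound 2 to compound 4 (0.02 log units; within the scatter), so the lower number seen with 4-methylphenyl does not recur. Even so, the two cores do not firmly separate the aryl exchange: the same change on two cores in this assay, a 1.2-fold higher number (0.10 log units; within the scatter) from compound 1 to compound 2 and a 2.5-fold higher number (0.39 log units; beyond the scatter) from compound 3 to compound 4, 2.0-fold (0.30 log units) apart, within the scatter of two such steps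

As far as these compounds go, whether this step follows the fluorine or its place on the ring stays open. Also open, from the compounds shown here alone, is how 4-fluorophenyl, or an amine in place of 2-hydroxyethoxy, would read in this assay.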